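Long-chain amides of the shared core: an unsaturated analogue

The source may report more compounds than this note shows. Statements on the series, on what has been measured and on what is new or still open speak of the compounds shown alone.

compound 1: `CCCCCCCCCCCCCCCCCC(=O)NCc1ccc(O)c(OC)c1` — > 10000 nM
compound 2: `CCCCCCCCCCCCCCCC(=O)NCc1ccc(O)c(OC)c1` — > 10000 nM
compound 3: `CCCCCCCC/C=C\CCCCCCCCCCCC(=O)NCc1ccc(O)c(OC)c1` — not yet measured

In an assay on HEK293 cells for antagonist activity at transient receptor potential cation channel subfamily V member 2 (Rattus norvegicus), read by fluorescence and calcium flux, with a stated time of 5 min (on this read-out higher numbers stand for weaker inhibition and lower numbers for stronger inhibition), compound 1 gives only a limit, > 10000 nM. Compound 2 likewise gives only a limit, > 10000 nM. The step that the two limits leave unreadable from compound 1 to compound 2 is therefore unreadable, both values sitting at the limit of > 10000 nM in this assay, at which 2 of the 2 values shown sit. Compound 3 differs from compound 2 by dec-1-en-1-yl in place of butyl on a saturated chain carbon, ten or more bonds along the chain from a carbonyl carbon. For the measured compounds named here, no measured step reads on this change, since the one step available is itself unreadable. The step of a number no higher from compound 2 to compound 3 (the limit leaves the size open) is expected to stay within the scatter. Compound 3 is thus expected near 10000 nM, between 3000 nM and 30000 nM, most likely reported again only as a limit.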

Compound 3, half-maximal inhibitory concentration: 1500 nM
Estimate against measurement, compound 3: 6.7-fold (0.82 log units) above; measured number below the stated range.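

In this assay, dec-1-en-1-yl in place of butyl, on a saturated chain carbon, gives an at least 6.6-fold lower number from compound 2 to compound 3 (0.82 log units; beyond the scatter). Dec-1-en-1-yl in place of hexyl at that place gives an at least 6.6-fold lower number from compound 1 to compound 3 (0.82 log units; beyond the scatter). This part of the chain can therefore move the read-out, which the unreadable step between compound 1 and compound 2 could not show: the limit of > 10000 nM in this assay, at which 2 of the 3 values shown sit.

On these data alone, the change adds carbons and a double bond together, so which of the two carries the step stays open. A saturated chain of the same length as in compound 3 and the trans double bond would separate these.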